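This account rests on a few compounds, and the source may have more. Where it says the series, first, only, none or still open, it means among the compounds named here.

Measured compounds in a functional assay on PBMC cells (Homo sapiens) for inhibition; on this read-out lower numbers stand for stronger inhibition and higher numbers for weaker inhibition:
- compound 1, `CC(C)C[C@H](N)C(=O)NS(=O)(=O)OC[C@H]1OC[C@@H](n2cnc3c(N)ncnc32)[C@H](O)[C@@H]1O`: 1000 nM
- compound 2, `Nc1ncnc2c1ncn2[C@@H]1CO[C@H](COS(=O)(=O)NC(=O)[C@@H]2CCCN2)[C@@H](O)[C@H]1O`: 750 nM

Compound 2 holds the lowest of the two numbers in this assay; its nearest neighbour is compound 1, and the gap between them is within the scatter, so the two cannot be ordered.

Compound 3, `N=C(N)NCCC[C@H](N)C(=O)NS(=O)(=O)OC[C@H]1OC[C@@H](n2cnc3c(N)ncnc32)[C@H](O)[C@@H]1O`, is not yet measured. It differs from compound 2 in one place: a group of 9 heavy atoms (5 carbon, 4 nitrogen; no ring) in place of a group of 5 heavy atoms (4 carbon, 1 nitrogen; one five-membered non-aromatic ring with 1 hetero atom), on a carbonyl carbon.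

Among the compounds with values here, the only measured step that bears on this exchange is the one on the same carbonyl carbon, a 1.3-fold lower number from compound 1 to compound 2 (0.12 log units; within the scatter), which stays within the scatter. Within the data shown here, that step swaps one group of this kind for another without moving the number, and no other step tells anything further about this position. Among the measured compounds shown here, the change to compound 3 is a different exchange, larger in the group that enters, so it is read with caution; still, on the one step at hand, no movement beyond the scatter is expected in either direction.

Compound 3 is therefore estimated at 800 nM in this assay, with a range of 300 nM to 2500 nM, which means an expected step of a 1.1-fold higher number from compound 2 to compound 3 (0.03 log units; within the scatter).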

Compound 3, half-maximal inhibitory concentration: 600 nM
Compound 3: middle estimate off by 1.3-fold (0.12 log units), on the high side; low and high end bracket the measured number.
By their numbers in this assay, from the lowest: compounds 3, 2 and 1 (each within the scatter of the next).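

In this assay, placing the open-chain group of 9 heavy atoms (5 carbon, 4 nitrogen; no ring) on the carbonyl carbon in place of pyrrolidin-2-yl gives a 1.3-fold lower number from compound 2 to compound 3 (0.10 log units; within the scatter) and so leaves the read-out unresolved, even though the entering group has no ring and carries 4 hydrogen-bond donors. Read against the 1-amino-3-methylbutyl compound, the exchange of one group without a ring for another on a saturated chain carbon gives a 1.7-fold lower number from compound 1 to compound 3 (0.22 log units; within the scatter) and likewise separates nothing, so the three groups shown at this position cannot be ordered despite their differences in size, ring content and nitrogen count. No supporting measurement bears on why these groups read alike.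

Whether any group on this carbonyl carbon moves the number beyond the scatter remains open, as the three compounds shown span only this narrow set of groups. A carboxylic acid or a phenyl ring on the saturated chain carbon, or a longer chain ending in a primary amine, would test whether this flat reading holds.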